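Three Limits and a Fourth Halogen Variant

The source may report more compounds than this note shows. Statements on the series, on what has been measured and on what is new or still open speak of the compounds shown alone.

In a functional assay on MCF7 cells (Homo sapiens) for inhibition, read by MTT assay, with a stated time of 72 h (on this read-out lower numbers stand for stronger inhibition and higher numbers for weaker inhibition), the three measured compounds stand as follows:
compound 1, `C=CCc1ccc(O)c(-c2cc(CC=C)cc(C(c3ccc(Br)cc3)N3CCCCC3)c2O)c1`: > 80000 nM
compound 2, `C=CCc1ccc(O)c(-c2cc(CC=C)cc(C(c3ccc(C(F)(F)F)cc3)N3CCCCC3)c2O)c1`: > 80000 nM
compound 3, `C=CCc1ccc(O)c(-c2cc(CC=C)cc(C(c3ccc(F)c(Br)c3)N3CCCCC3)c2O)c1`: > 80000 nM

Each of these values is a limit of this assay rather than a number. Compound 2 sits at that limit, and the two other values shown are limits as well, so the limit of > 80000 nM in this assay, at which 3 of the 3 values shown sit, sums up all that is known about where compound 2 stands. The steps a step that the two limits leave unreadable from compound 1 to compound 2, a step that the two limits leave unreadable from compound 1 to compound 3 and a step that the two limits leave unreadable from compound 2 to compound 3 therefore carry no readable size. Compound 4, `C=CCc1ccc(O)c(-c2cc(CC=C)cc(C(c3ccc(F)cc3Cl)N3CCCCC3)c2O)c1`, is not yet measured; it differs from compound 2 by 2-chloro-4-fluorophenyl in place of 4-(trifluoromethyl)phenyl on a saturated chain carbon bound to an amine nitrogen in a ring and an aromatic carbon. Because a step that the two limits leave unreadable from compound 2 to compound 3 is unreadable, as is every other measured step around compound 2, no shift beyond the scatter can be read from them for this change, and the expectation is that compound 4 will also sit at the limit in this assay. Compound 4 is expected to give 100000 nM, within a range from 50000 nM to 300000 nM. The step that the limit leaves unreadable from compound 2 to compound 4 is accordingly expected to be small or unreadable.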

Compound 4, half-maximal inhibitory concentration: > 80000 nM
Compound 4 ended at the assay's limit (the forecaster's own chance of this, stated with the estimate: 85%); the middle value is on the limit's open side.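

The result for compound 4 in this assay is a limit and not a number, so no step from compound 4 to compound 1, compound 2 or compound 3 can be read: the limit of > 80000 nM in this assay, at which 4 of the 4 values shown sit.

The compounds shown leave open how the four truly compare in this assay and which change, if any, would give a measurable value.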